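The source may hold more compounds than are shown below. What is called first, only, known or untested is meant among the compounds shown, and "the series" means these compounds.

Compound 1 `CCCCCCSC[C@H](NC(C)=O)C(=O)CCl`, compound 2 `CCCCCCCSC[C@H](NC(C)=O)C(=O)CCl`, compound 3 `CCCCCCCCCSC[C@H](NC(C)=O)C(=O)CCl` and compound 4 `CCCCCCCCCCSC[C@H](NC(C)=O)C(=O)CCl` share one core and differ only in the length of the saturated chain that hangs on the sulfur. In a functional assay on MOLT-3 cells (Homo sapiens) (on this read-out higher numbers stand for weaker inhibition and lower numbers for stronger inhibition), compound 1 gives 700 nM. Compound 2 gives 2500 nM, and compound 3 gives 6700 nM. The change from compound 1 to compound 2 is methyl in place of hydrogen on a saturated chain carbon, six bonds along the chain from a sulfur, and it made a 3.6-fold higher number from compound 1 to compound 2 (0.55 log units; beyond the scatter). Lengthening the chain further gave a 9.6-fold higher number from compound 1 to compound 3 (0.98 log units; beyond the scatter) and a 2.7-fold higher number from compound 2 to compound 3 (0.43 log units; beyond the scatter), so every added carbon so far has pushed the number upward, and none of the three measured compounds goes against that.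

Compound 4 has not yet been measured in this assay. Against compound 3 it carries methyl in place of hydrogen on a saturated chain carbon, nine bonds along the chain from a sulfur. For the measured compounds named here, this is the same kind of change as the one from compound 1 to compound 2, but not the same: there the methyl enters six bonds along the chain from a sulfur, here nine bonds along the chain from a sulfur. The cores of compound 1 and compound 3 also differ, by propyl in place of hydrogen on a saturated chain carbon, six bonds along the chain from a sulfur. From compound 3 to compound 4 the step is expected to be a 2.5-fold higher number from compound 3 to compound 4 (0.40 log units; beyond the scatter), set beside the earlier 3.6-fold higher number from compound 1 to compound 2 (0.55 log units; beyond the scatter). That expectation rests on the two earlier steps, a 3.6-fold higher number from compound 1 to compound 2 (0.55 log units; beyond the scatter) and a 2.7-fold higher number from compound 2 to compound 3 (0.43 log units; beyond the scatter), which both pointed the same way and were of similar size. For compound 4 the estimate is 17000 nM, with the likely range running from 8000 nM to 36000 nM.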

Compound 4, half-maximal inhibitory concentration: 3400 nM
For compound 4 the middle estimate is 5.0-fold (0.70 log units) above the measured one; the whole stated range lies above it.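

For the compounds shown here, the same added group does not carry over from core to core, at least in this assay, as the methyl change shows: the same change on two cores in this assay, a 3.6-fold higher number (0.55 log units; beyond the scatter) from compound 1 to compound 2 and a 2.0-fold lower number (0.29 log units; within the scatter) from compound 3 to compound 4, 7.0-fold (0.85 log units) apart, beyond the scatter of two such steps The larger change, propyl in place of hydrogen, departs in the same way: the same change on two cores in this assay, a 9.6-fold higher number (0.98 log units; beyond the scatter) from compound 1 to compound 3 and a 1.4-fold higher number (0.13 log units; within the scatter) from compound 2 to compound 4, 7.0-fold (0.85 log units) apart, beyond the scatter of two such steps The new steps, a 2.0-fold lower number from compound 3 to compound 4 (0.29 log units; within the scatter) and a 1.4-fold higher number from compound 2 to compound 4 (0.13 log units; within the scatter), leave those two pairs indistinguishable, while a 4.9-fold higher number from compound 1 to compound 4 (0.69 log units; beyond the scatter) remains a real difference, so the steady rise seen across compound 1, compound 2 and compound 3 does not extend to compound 4, the one compound that goes against it; these figures show that the effect of adding carbon depends on the length of the chain already present, but they do not show why, and with single values for each compound they cannot say where the rise stops.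

The compounds shown leave open how a longer chain than that of compound 4 would read in this assay, and whether the number would stay level or move again. They also leave open what a branched chain, or a chain carrying a hydroxyl group, would do on the shared core.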